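This account rests on a few compounds, and the source may have more. Where it says the series, first, only, none or still open, it means among the compounds named here.

Measured so far:
compound 1, `Nc1scc(CN2CCN(c3ccc(OC(F)(F)F)cc3)CC2)c1C(=O)c1ccc(Cl)cc1`, -51%
compound 2, `Nc1scc(CN2CCN(c3cccc(F)c3)CC2)c1C(=O)c1ccc(Cl)cc1`, -86%
compound 3, `Nc1scc(CN2CCN(c3ccc(F)c(Cl)c3)CC2)c1C(=O)c1ccc(Cl)cc1`, -60%

In a functional assay on CHO cells with adenosine receptor A1 (Homo sapiens) as the target, read by cAMP accumulation and immunoassay, with a stated time of 6 min, tested at 1 uM (on this read-out lower numbers stand for a stronger effect and higher numbers for a weaker effect at the one concentration tested), compound 3 stands second highest of the three numbers; its nearest neighbour is compound 1, as a number 9 percentage points lower from compound 1 to compound 3 (within the scatter) shows, and its furthest is compound 2, as a number 26 percentage points higher from compound 2 to compound 3 (beyond the scatter) shows. Compound 4, `Nc1scc(CN2CCN(c3cc(Cl)ccc3Cl)CC2)c1C(=O)c1ccc(Cl)cc1`, differs from compound 3 in one place: 2,5-dichlorophenyl in place of 3-chloro-4-fluorophenyl on an amine nitrogen in a ring. Within the data shown here, no measured step makes exactly this exchange; the ones that bear on it are the other swaps of the group on the ring nitrogen, a number 35 percentage points lower from compound 1 to compound 2 (beyond the scatter), a number 26 percentage points higher from compound 2 to compound 3 (beyond the scatter) and a number 9 percentage points lower from compound 1 to compound 3 (within the scatter), one large, one modest and one within the scatter. A modest step in either direction, or none beyond the scatter, is therefore expected. Compound 4 is estimated at -62%, between -85% and -40%, an expected a number 2 percentage points lower from compound 3 to compound 4 (within the scatter).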

Compound 4, a percentage reported as activity, at one concentration (the size of the read-out at that concentration, not a potency): -42%
Compound 4: the middle estimate sits 20 percentage points below what was measured, and the stated range covers the measured number.
By their numbers in this assay, from the lowest: compound 2; then compounds 3, 1 and 4 (each within the scatter of the next, the first and the last beyond it).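

In this assay, replacing 3-chloro-4-fluorophenyl with 2,5-dichlorophenyl, which has the same count of heavy atoms and no added hydrogen-bond donors or acceptors, still gives a number 18 percentage points higher from compound 3 to compound 4 (beyond the scatter). The 3-fluorophenyl of compound 2 keeps its distance from the new group, with a number 44 percentage points higher from compound 2 to compound 4 (beyond the scatter), whereas the 4-(trifluoromethoxy)phenyl of compound 1 cannot be separated from it, with a number 9 percentage points higher from compound 1 to compound 4 (within the scatter). Nothing given here accounts for these differences. The compounds shown leave open how an unsubstituted phenyl or a methoxyphenyl on this ring nitrogen would read.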